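The source may report more compounds than this note shows. Statements on the series, on what has been measured and on what is new or still open speak of the compounds shown alone.

In an assay on cells for displacement of a labelled ligand from C-X-C chemokine receptor type 4 (Homo sapiens), read by fluorescence and microscopy, with stated times of 10 min and 30 min (on this read-out lower numbers stand for an effect already at smaller amounts and higher numbers for an effect only at larger amounts of compound), three compounds sharing one core have been measured so far. Compound 1 `O=C(NCc1ccc(CNS(=O)(=O)c2ccc(F)c(F)c2)cc1)c1cnc2ccccn12` gives > 1000 nM, which is a limit of the assay rather than a number (the limit of > 1000 nM in this assay, at which 1 of the 3 values shown sits). Compound 3 `Cc1nnsc1C(=O)NCc1ccc(CNS(=O)(=O)c2ccc(F)c(F)c2)cc1` gives 10 nM, and the step of an at least 100-fold lower number from compound 1 to compound 3 (2.00 log units; beyond the scatter) is large, arising from exchanging the group on the carbonyl carbon. Compound 2 `O=C(NCc1ccc(CNS(=O)(=O)c2ccc3c(c2)CCO3)cc1)c1scc2c1OCCO2` gives 10 nM, level with compound 3 at the digits shown and within the scatter of it, so no order between the two can be stated. Compound 4 `Cn1nccc1C(=O)NCc1ccc(CNS(=O)(=O)c2ccc3c(c2)CCO3)cc1` has not been measured; it differs from compound 2 by a group of 6 heavy atoms (4 carbon, 2 nitrogen; one five-membered aromatic ring with 2 hetero atoms) in place of a group of 9 heavy atoms (6 carbon, 2 oxygen, 1 sulfur; one five-membered aromatic ring with 1 hetero atom, one six-membered non-aromatic ring with 2 hetero atoms), on a carbonyl carbon. Within the data shown here, the only measured step at a carbonyl carbon is the exchange from compound 1 to compound 3, which was large, yet compound 3 holds one five-membered aromatic ring with 3 hetero atoms on that carbonyl and sits at 10 nM, a small ring like the one entering here. A step of a 2.0-fold higher number from compound 2 to compound 4 (0.30 log units; within the scatter) is therefore expected, not beyond the scatter. The estimate for compound 4 in this assay is 20 nM, expected between 5 nM and 100 nM.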

Compound 4, effective concentration (reported as EC, without a stated level of effect): 1000 nM
Beside the measured number, compound 4's estimate is 50-fold (1.70 log units) below it; measured number above the stated range.
By their numbers in this assay, from the lowest: compounds 2 and 3 (each within the scatter of the next); then compound 4.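

In this assay, the exchange on the carbonyl carbon gives a 100-fold higher number from compound 2 to compound 4 (2.00 log units; beyond the scatter), so this position is again highly sensitive to the group it carries. The earlier step at this position, an at least 100-fold lower number from compound 1 to compound 3 (2.00 log units; beyond the scatter), also replaced a larger group with a smaller five-membered aromatic ring, but there the number fell, whereas here it rises. Group size alone therefore does not set the direction of the change in these two pairs, and the five-membered aromatic ring with 2 hetero atoms does not hold the value of the group it replaces. The limit belongs to compound 1, whereas the value of compound 4 is a number: the limit of > 1000 nM in this assay, at which 1 of the 4 values shown sits.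

The compounds shown leave open which atoms of the group in compound 2 matter, and whether the sulfonyl side alters the outcome. They also leave open how a plain phenyl ring or a piperidine would behave on this carbonyl carbon.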